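This account rests on a few compounds, and the source may have more. Where it says the series, first, only, none or still open, it means among the compounds named here.

Compound 1 `CC(=O)NN1C(=O)/C(=C/c2ccccc2)SC1=S`: "not active" (no number reported)
Compound 2 `COc1cc(OC)c(OC)cc1/C=N/n1c(S)nnc1-c1ccc(C)cc1`: > 200000 nM

In an assay for inhibition of LL-diaminopimelate aminotransferase, chloroplastic (Arabidopsis thaliana) (on this read-out lower numbers stand for stronger inhibition and higher numbers for weaker inhibition), compound 1 is reported as "not active" (no number reported), so no single number places it. Compound 2 sits at a limit of this assay, > 200000 nM, and the one listed boundary is the limit of > 200000 nM in this assay, at which 1 of the 2 values shown sits. Compound 3 `COc1ccc(/C=C2\SC(=S)N(NC(C)=O)C2=O)cc1` differs from compound 1 by methoxy in place of hydrogen on an aromatic carbon. Among the compounds with values here, with no measured step of this kind, the change is not expected to move the read-out beyond the usual scatter. Compound 3 is therefore estimated at 200000 nM, with a range from 50000 nM to 600000 nM.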

Compound 3, half-maximal inhibitory concentration: > 200000 nM
Compound 3 ended at the assay's limit; the forecaster's own chance of this, stated with the estimate: 85%; the middle value sits exactly at the limit.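

In this assay compound 3 gives > 200000 nM, which is a limit of the assay. Compound 1 carries no number, so no step can be read between compound 1 and compound 3. The compounds shown leave open what methoxy in place of hydrogen does to the read-out, and how strongly any of them inhibits.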